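The source may hold more compounds than are shown below. What is called first, only, known or untested is meant among the compounds shown, and "the series" means these compounds.

For the measured compounds named here, in an ADME assay on HepG2 cells (Homo sapiens) for cytotoxicity, read by MTT assay, with a stated time of 24 h (a lower number here means that less compound is tolerated, a higher number that more compound is tolerated), compound 2 (`OCCCc1cn(-c2ccnc3cc(Cl)ccc23)nn1`) gives 151000 nM as the only true number so far. Compound 1 (`Fc1ccc(-c2cn(-c3ccnc4cc(Cl)ccc34)nn2)cc1`) gives > 3080000 nM as a limit of the assay. Compound 3 (`Cc1ccc(C(=O)OCCCc2cn(-c3ccnc4cc(Cl)ccc34)nn2)cc1`) gives > 2460000 nM as a limit too. Compound 2 is thus the low point of the three, with an at least 20-fold lower number from compound 1 to compound 2 (1.30 log units; beyond the scatter) on one side and an at least 16-fold higher number from compound 2 to compound 3 (1.21 log units; beyond the scatter) on the other, both large and beyond the scatter.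

Compound 4 (`CCN(CC)Cc1cn(-c2ccnc3cc(Cl)ccc23)nn1`) is not yet measured: diethylamino stands in place of 2-hydroxyethyl on a saturated chain carbon bound to an aromatic carbon (diethylamino in place of 2-hydroxyethyl on a saturated chain carbon bound to an aromatic carbon). Neither measured step makes this exchange. Compound 3 is the closer guide, as it too loses the hydrogen on the oxygen, and its step is upward. The group entering here is much smaller, so a far more modest rise is expected in this assay than either measured step. The expected change is a 2.3-fold higher number from compound 2 to compound 4 (0.37 log units; beyond the scatter) as a working estimate. For compound 4 the estimated value is 350000 nM with an expected range from 90000 nM to 1800000 nM in this assay.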

Compound 4, half-maximal cytotoxic concentration: 1850000 nM
The estimate for compound 4 lay 5.3-fold (0.72 log units) below the measured number, and the stated range ends below it.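

In this assay, the step with a 12-fold higher number from compound 2 to compound 4 (1.09 log units; beyond the scatter) shows that a large rise at this place needs no ring in the entering group: diethylamino has none, yet the number moves far beyond the scatter. Compound 2, with its free hydroxyl, thus stays the low point against compound 4 as well as against the two ring-bearing compounds. Against 4-fluorophenyl, the exchange gives an at least 1.6-fold lower number from compound 1 to compound 4 (0.22 log units; that floor lies within the scatter), and this is only a floor, as the value of compound 1 is a limit: the limit of > 3080000 nM in this assay, at which 1 of the 4 values shown sits.

Going by these compounds, whether the rise goes with the loss of the hydroxyl or with the entry of the diethylamino nitrogen stays open. A methoxy group or a plain butyl chain in this place would separate the two, and a primary amine would show whether the ethyl groups matter.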